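The compounds below may be only part of what the source reports. "The series", "measured", "known", "first", "only" and "open" are said of these compounds alone.

Measured so far in a physicochemical assay for lipophilicity, using the shake flask method, in phosphate buffer, measured as octanol-water partition, with a stated time of 5 h, at pH 7.4; a higher number here means a more lipophilic compound, a lower number a more polar compound:
- compound 1 `CN1CCN(c2cc(Nc3ncc(Br)c(Nc4cccc(CO)c4)n3)cc(S(C)(=O)=O)c2)CC1`: 2.43
- compound 2 `CN1CCN(c2cc(Nc3ncc(Cl)c(Nc4cccc(CO)c4)n3)cc(S(C)(=O)=O)c2)CC1`: 2.16
- compound 3 `Cc1cnc(Nc2cc(N3C[C@@H](C)N[C@@H](C)C3)cc(S(C)(=O)=O)c2)nc1Nc1cccc(CO)c1`: 1.24

Compound 2, at 2.16, cannot be told apart from compound 1 within the usual scatter, while compound 3 lies clearly beneath it. Compound 4 `Cc1cnc(Nc2cc(N3CCN(C)CC3)cc(S(C)(=O)=O)c2)nc1Nc1cccc(CO)c1` has not yet been measured. It differs from compound 2 by a single change, methyl in place of chloro on an aromatic carbon.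

Going by the values given here, only one measured step swaps one group for another at an aromatic carbon with all else equal: chloro in place of bromo gave a number 0.27 log units lower from compound 1 to compound 2 (within the scatter). That step is small, and it involves a different pair of groups, so it serves only as a rough guide to size. Compound 3, at 1.24, also carries the methyl but differs elsewhere too, so it gives only a weak hint of a lower number. A modest downward move in this assay is therefore expected, and the estimated step is a number 0.36 log units lower from compound 2 to compound 4 (beyond the scatter). For compound 4 the expected value is 1.8, with an estimated range from 1.4 to 2.2.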

Compound 4, distribution coefficient: 1.74
The estimate for compound 4 lay 0.06 log units above the measured number; the measured number falls inside the stated range.
By their numbers in this assay, from the lowest: compound 3; then compound 4; then compounds 2 and 1 (each within the scatter of the next).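

In this assay, methyl on this aromatic carbon, ortho to a (3-(hydroxymethyl)phenyl)amino group, gives a number 0.42 log units lower from compound 2 to compound 4 (beyond the scatter) and a number 0.69 log units lower from compound 1 to compound 4 (beyond the scatter). Going by these compounds alone, the earlier swap of bromo for chloro at the same carbon stayed within the scatter, so compound 4 is the first sign that a change here can shift the number beyond it. With the methyl kept in place, a change elsewhere also counts: 4-methylpiperazin-1-yl in place of 3,5-dimethylpiperazin-1-yl gives a number 0.50 log units higher from compound 3 to compound 4 (beyond the scatter).

The compounds shown offer no measured explanation for any of these steps. Going by these compounds, whether fluoro, ethyl or methoxy on this carbon would land near methyl or near chloro and bromo remains open.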